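The source may report more compounds than this note shows. Statements on the series, on what has been measured and on what is new or still open speak of the compounds shown alone.

Measured in a functional assay on KG-1 cells (Homo sapiens) for cytotoxicity, read by luminescence and CellTiter-Glo, with a stated time of 3 days (a lower number here means a stronger inhibitor, a higher number a weaker inhibitor), so far:
- compound 1 `Cc1ccc(C(=O)Nc2ccc(C#N)cc2)c(O)c1` gives 2560 nM
- compound 2 `COc1ccc(C(=O)Nc2ccc(C#N)cc2)c(O)c1` gives 5430 nM
- compound 3 `N#Cc1ccc(NC(=O)c2ccc(F)cc2O)cc1` gives 3150 nM

Compound 3 stands within the scatter of both other compounds, with a 1.2-fold higher number from compound 1 to compound 3 (0.09 log units; within the scatter) and a 1.7-fold lower number from compound 2 to compound 3 (0.24 log units; within the scatter) as its two steps. Within the data shown here, only one pair separates beyond the scatter, with a 2.1-fold higher number from compound 1 to compound 2 (0.33 log units; beyond the scatter) as a modest step.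

Next in the series is compound 4 `N#Cc1ccc(NC(=O)c2ccc(-c3ccncc3)cc2O)cc1` with pyridin-4-yl in place of fluoro on an aromatic carbon (that is, (pyridin-4-yl in place of fluoro on an aromatic carbon)). All three measured steps exchange groups at this same carbon, so they bear directly on the change. None of them brings in a ring, however, so they guide it only weakly. Their largest size, seen in a 2.1-fold higher number from compound 1 to compound 2 (0.33 log units; beyond the scatter) as the modest step, suggests a flat response at this carbon.

On these data alone, no step beyond the scatter is therefore expected in this assay and the direction remains open, with the estimated step being a 1.3-fold lower number from compound 3 to compound 4 (0.10 log units; within the scatter) (a wide uncertainty applies). The estimate for compound 4 is 2500 nM (expected range 500 nM to 9000 nM).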

Compound 4, half-maximal inhibitory concentration: 8840 nM
Compound 4: the middle estimate sits 3.5-fold (0.55 log units) below what was measured; low and high end bracket the measured number.
By their numbers in this assay, from the lowest: compounds 1, 3, 2 and 4 (each within the scatter of the next, the first and the last beyond it).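

In this assay, this carbon, para to a large group and meta to a hydroxy group, now carries a ring, and the flat response among the small groups no longer holds: a 2.8-fold higher number from compound 3 to compound 4 (0.45 log units; beyond the scatter) and a 3.5-fold higher number from compound 1 to compound 4 (0.54 log units; beyond the scatter) both lie beyond the scatter. The ring is not set apart from every small group, however, as a 1.6-fold higher number from compound 2 to compound 4 (0.21 log units; within the scatter) stays within the scatter, so compound 2 goes against any simple split between ring and small substituent. No measured evidence on the cause of these steps is at hand.

On these data alone, it remains open whether the higher numbers follow the ring as such or its ring nitrogen, which a plain phenyl ring at this carbon would separate. As far as these compounds go, how an amine or a carboxylic acid would behave here also remains open.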